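Chloro for Isopropyl on an Unmeasured Core

A few compounds are considered here, and "the series" means these few. Any claim that something is new, unique, unknown or untested is made for them only; others in the source may bear on it.

Compound 1 `Cc1cnc(Nc2ccc(C(C)C)cc2)nc1Nc1nc2ccccc2s1`: > 50000 nM in a functional assay on PC-3 cells (Homo sapiens) for antiproliferative activity, read by MTT assay, with a stated time of 48 h; a lower number here means a stronger inhibitor, a higher number a weaker inhibitor
Compound 2 `CS(=O)(=O)c1ccc(Nc2nccc(Nc3nc4ccc(F)cc4s3)n2)cc1`: 1940 nM in this assay

For compound 1 the assay reports only a limit, not a number, at the limit of > 50000 nM in this assay, at which 1 of the 2 values shown sits. Among the compounds with values here, compound 2 gives a number in this assay, 1940 nM, but no single-change step links it to compound 1, so only the two values stand side by side. Compound 3 `Cc1cnc(Nc2ccc(Cl)cc2)nc1Nc1nc2ccccc2s1` is not yet measured; it differs from compound 1 by chloro in place of isopropyl on an aromatic carbon. With compound 1 at the limit, no measured step shows the size of this change; a step beyond the scatter toward stronger inhibition cannot be ruled out, but none is shown. Compound 3 is estimated at 40000 nM, between 8000 nM and 100000 nM, an expected step of an at least 1.2-fold lower number from compound 1 to compound 3 (0.09 log units; that floor lies within the scatter).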

Compound 3, half-maximal inhibitory concentration: > 50000 nM
Compound 3 gave a limit, no number (the forecaster's own chance of this, stated with the estimate: 55%); at least 1.2-fold (0.09 log units) between middle value and limit.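

Compound 1 and compound 3 both stand at a limit rather than a number, so no step between them can be read: the limit of > 50000 nM in this assay, at which 2 of the 3 values shown sit.

As far as these compounds go, how far isopropyl and chloro on the shared core differ in this assay stays open.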